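A few compounds are considered here, and "the series" means these few. Any claim that something is new, unique, unknown or untested is made for them only; others in the source may bear on it.

Compound 1 `Nc1ccccc1NC(=O)c1ccc(CSC(=S)N2CCc3ccccc32)cc1` gives 44% in a functional assay on MGC-803 cells (Homo sapiens) for antiproliferative activity, read by CCK-8 assay, with a stated time of 72 h, tested at 2 uM; a higher number here means a stronger effect of the compound at the concentration tested, a lower number a weaker effect. Compound 2 `Nc1ccccc1NC(=O)c1ccc(CSC(=S)N2CCCc3ccccc32)cc1` gives 38.5% in this assay, standing nearest compound 1 with a number 5.5 percentage points lower from compound 1 to compound 2 (within the scatter), a shift within the scatter and so not a real difference. Compound 3 `CCN(Cc1ccncc1)C(=S)SCc1ccc(C(=O)Nc2ccccc2N)cc1` carries ethyl((pyridin-4-yl)methyl)amino in place of 1,2,3,4-tetrahydroquinolin-1-yl on a thiocarbonyl carbon. For the measured compounds named here, the one measured step, from compound 1 to compound 2, exchanged one amine on the thiocarbonyl carbon for another without an effect beyond the scatter, but no step yet covers an amine like the one entering here. Compound 3 is therefore expected to stay close, with a number 0.5 percentage points lower from compound 2 to compound 3 (within the scatter), estimated at 38% within 22% to 54%.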

Compound 3, a percentage reported as inhibition, at one concentration (the size of the read-out at that concentration, not a potency): 71.6%
Compound 3: the middle estimate sits 33.6 percentage points below what was measured; the whole stated range lies below it.
By their numbers in this assay, from the lowest: compounds 2 and 1 (each within the scatter of the next); then compound 3.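

In this assay the amine on the thiocarbonyl carbon proves able to move the read-out: ethyl((pyridin-4-yl)methyl)amino gives a number 33.1 percentage points higher from compound 2 to compound 3 (beyond the scatter) and a number 27.6 percentage points higher from compound 1 to compound 3 (beyond the scatter) while the two earlier amines stay within the scatter of each other. Among these three compounds, only this amine, which is not a ring closed onto the nitrogen, stands apart. Nothing available here accounts for the gain. As far as these compounds go, it remains open which part of the entering group carries the step, the ethyl or the pyridin-4-yl. From the compounds shown here alone, whether a phenyl in place of the pyridin-4-yl, or a propyl in place of the ethyl, would hold the number is also open.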